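Phenyl substituent change from compound 2 to compound 3

This account rests on a few compounds, and the source may have more. Where it says the series, first, only, none or still open, it means among the compounds named here.

Within the data shown here, compound 2 `CCCc1cc(N)c2cc(NC(=O)/C=C/c3ccc(I)cc3)ccc2n1` gives 280 nM in a functional assay on HEK293 cells for activation of melanin-concentrating hormone receptor 1 (Homo sapiens), read by inositol phosphate accumulation (a higher number here means that more compound is needed for the effect, a lower number that less compound is needed), the lower of the two numbers so far; compound 1 `CCCc1ccc(/C=C/C(=O)Nc2ccc3nc(CCC)cc(N)c3c2)cc1` gives 3600 nM. Among the measured compounds shown here, the single measured step, a 13-fold lower number from compound 1 to compound 2 (1.11 log units; beyond the scatter), shows a halogen on that phenyl reading far lower than propyl. Compound 3 `CCCc1cc(N)c2cc(NC(=O)/C=C/c3ccc(Cl)cc3Cl)ccc2n1` carries 2,4-dichlorophenyl in place of 4-iodophenyl on a double-bonded chain carbon bound to a double-bonded chain carbon. For the measured compounds named here, no measured step exchanges one halogen for another or adds a second chlorine, so this change has no direct precedent; it keeps a halogen on the phenyl where compound 2 reads well. For compound 3 the expected step is a 1.3-fold higher number from compound 2 to compound 3 (0.10 log units; within the scatter), with an estimate of 350 nM and a range of 110 nM to 1200 nM.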

Compound 3, half-maximal effective concentration: 904 nM
Compound 3: middle estimate off by 2.6-fold (0.41 log units), on the low side; the range from low to high includes it.
By their numbers in this assay, from the lowest: compound 2; then compound 3; then compound 1.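

In this assay, two halogen patterns on this phenyl no longer read alike: a 3.2-fold higher number from compound 2 to compound 3 (0.51 log units; beyond the scatter), so 2,4-dichlorophenyl does not match 4-iodophenyl. Halogen still reads better than propyl here, with a 4.0-fold lower number from compound 1 to compound 3 (0.60 log units; beyond the scatter), placing 2,4-dichlorophenyl between 4-iodophenyl and 4-propylphenyl. Nothing measured bears on why these groups differ. The halogen and the substitution pattern change together. The step cannot be assigned to either alone. As far as these compounds go, whether bromo, a single chlorine or methoxy on the phenyl would read nearer compound 2 remains open.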